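The source may report more compounds than this note shows. Statements on the series, on what has been measured and on what is new or still open speak of the compounds shown alone.

Measured compounds:
- compound 1, `O=C(N/N=C/c1cccc(F)c1)c1cccnc1Nc1cccc(C(F)(F)F)c1`, 37%
- compound 2, `COc1cccc(/C=N/NC(=O)c2cccnc2Nc2cccc(C(F)(F)F)c2)c1`, 30.3%
- compound 3, `COc1ccc(/C=N/NC(=O)c2cccnc2Nc2cccc(C(F)(F)F)c2)cc1`, 26.5%

All three were tested in a functional assay on the whole organism (strain Wistar) for inhibition, with Rattus norvegicus as the target, read by paw edema, with a stated time of 3 h, at a dose of 10 mg/kg by the intraperitoneal route; a lower number here means less inhibition, a higher number more inhibition at the dose given (going by the name of the read-out). Compound 3 has the lowest of the three numbers: its nearest neighbour is compound 2, and that gap, a number 3.8 percentage points lower from compound 2 to compound 3 (within the scatter), lies within the scatter; its furthest is compound 1, and that gap, a number 10.5 percentage points lower from compound 1 to compound 3 (beyond the scatter), lies beyond the scatter. Among the compounds with values here, compound 3 is therefore only the one with the lowest reading; against compound 2 its number is level.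

Compound 4, `O=C(N/N=C/c1ccncc1)c1cccnc1Nc1cccc(C(F)(F)F)c1`, is not yet measured. It differs from compound 3 in one place: pyridin-4-yl in place of 4-methoxyphenyl on a carbon with a double bond to nitrogen. The measured steps that bear on this are the two in which the group on this same carbon was altered: a number 10.5 percentage points lower from compound 1 to compound 3 (beyond the scatter) and a number 3.8 percentage points lower from compound 2 to compound 3 (within the scatter), one modest and one within the scatter, and also a number 6.7 percentage points lower from compound 1 to compound 2 (within the scatter), within the scatter. None of them exchanges the ring itself for one with a ring nitrogen, so the direction for compound 4 is open. Given that these changes moved the readings only slightly, the step of a number 1.5 percentage points higher from compound 3 to compound 4 (within the scatter) is expected to stay within the scatter. Compound 4 is estimated at 28%, with a range from 15% to 42%.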

Compound 4, a percentage reported as inhibition, in the whole organism at one dose (the size of the read-out at that dose, not a potency): 54.9%
Compound 4: the middle estimate sits 26.9 percentage points below what was measured; the whole stated range lies below it.
By their numbers in this assay, from the lowest: compounds 3, 2 and 1 (each within the scatter of the next, the first and the last beyond it); then compound 4.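

In this assay the exchange of a carbon-only ring for pyridin-4-yl on the carbon with a double bond to nitrogen gives a number 28.4 percentage points higher from compound 3 to compound 4 (beyond the scatter) and a number 24.6 percentage points higher from compound 2 to compound 4 (beyond the scatter) and also a number 17.9 percentage points higher from compound 1 to compound 4 (beyond the scatter) and so places compound 4 above all three earlier compounds. Among those earlier compounds the ring stayed carbon-only and only its substituent changed, and the largest step was a number 10.5 percentage points lower from compound 1 to compound 3 (beyond the scatter) while the other two stayed within the scatter, so this position can respond far more strongly to a change in the ring itself than they suggested. No measurement here explains why the reading rises with this change.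

The compounds shown cannot separate the effect of the ring nitrogen from the loss of the methoxy or fluoro substituent, since a plain phenyl ring with neither group is not among them. They also leave open whether the nitrogen must sit as it does in pyridin-4-yl, a question that pyridin-3-yl or pyridin-2-yl on the same carbon would address.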